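This account rests on a few compounds, and the source may have more. Where it says the series, first, only, none or still open, it means among the compounds named here.

Values in an ADME assay on J774.1 cells (Mus musculus) for cytotoxicity, read by resazurin assay, with a stated time of 48 h; a higher number here means a weaker inhibitor, a lower number a stronger inhibitor:
- compound 1 `CCCn1cc(C(=O)NCc2ccccc2)c(=O)c2cc(F)c(N3CCC(C(N)=O)CC3)cc21`: 43700 nM
- compound 2 `CCCn1cc(C(=O)NCc2ccco2)c(=O)c2cc(F)c(N3CCC(C(N)=O)CC3)cc21`: 56900 nM
- compound 3 `NC(=O)C1CCN(c2cc3c(cc2F)c(=O)c(C(=O)NCc2ccccc2)cn3C2CC2)CC1`: 51200 nM

Compound 3 is not separated from the other two compounds, as all three values lie within the scatter of each other. Compound 4 `NC(=O)C1CCN(c2cc3c(cc2F)c(=O)c(C(=O)NCc2ccco2)cn3C2CC2)CC1` has furan-2-yl in place of phenyl on a saturated chain carbon bound to an amide-type nitrogen. The same replacement has one measured precedent, a 1.3-fold higher number from compound 1 to compound 2 (0.11 log units; within the scatter). The cyclopropyl in place of propyl on an aromatic nitrogen, shared by compound 3 and compound 4, gave a 1.2-fold higher number from compound 1 to compound 3 (0.07 log units; within the scatter). No step beyond the scatter is therefore expected in this assay. The expected change is a 1.2-fold higher number from compound 3 to compound 4 (0.08 log units; within the scatter). Compound 4 is estimated at 62000 nM, with an expected range of 40000 nM to 95000 nM.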

Compound 4, half-maximal inhibitory concentration: > 100000 nM
Compound 4: a limit, no number (the forecaster's own chance of this, stated with the estimate: 10%); middle value at least 1.6-fold (0.20 log units) away from the limit.
By their numbers in this assay, from the lowest: compounds 1, 3 and 2 (each within the scatter of the next). At a limit, above all of these: compound 4.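

In this assay compound 4 gives > 100000 nM, which is a limit of the assay and not a number. The pair now reads on both sides of the square, with an at least 1.9-fold higher number from compound 3 to compound 4 (0.29 log units; that floor lies within the scatter) for furan-2-yl in place of phenyl and an at least 1.7-fold higher number from compound 2 to compound 4 (0.24 log units; that floor lies within the scatter) for cyclopropyl in place of propyl on an aromatic nitrogen, so neither change is yet shown to pass the scatter. Whether the furan-2-yl change depends on the core stays unresolved: the same change on two cores in this assay, a 1.3-fold higher number (0.11 log units; within the scatter) from compound 1 to compound 2 and an at least 1.9-fold higher number (0.29 log units; that floor lies within the scatter) from compound 3 to compound 4; the limit leaves it open whether they differ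

On these data alone, whether the two changes combine beyond the scatter remains open without a number for compound 4. Also open, as far as these compounds go, is how thiophen-2-yl in place of furan-2-yl, or a butyl chain on the aromatic nitrogen, would read in this assay.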